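The source may hold more compounds than are shown below. What is called first, only, known or untested is meant among the compounds shown, and "the series" means these compounds.

Measured in a functional assay on the whole organism for antagonist activity, with Mus musculus as the target; a lower number here means that less compound is needed, a higher number that more compound is needed for the effect:
- Compound 1 `CC(=O)N(C)C(C)C#CCn1cncc1C`: 80 mg/kg
- Compound 2 `CCOC(=O)N(C)CC#CCN1CCCC1`: > 100 mg/kg (a limit)
- Compound 3 `CCOC(=O)N(C)C(C)C#CCN1CCCC1`: > 100 mg/kg (a limit)

Compound 3 has no numerical value in this assay. Its result of > 100 mg/kg is a limit of the assay and not a number. Compound 2 has the same kind of result, and its > 100 mg/kg is also a limit.

The next compound, compound 4 `CCOC(=O)N(C)C(C)C#CCn1cncc1C`, differs from compound 3 by 5-methyl-1H-imidazol-1-yl in place of pyrrolidin-1-yl on a saturated chain carbon bound to a triple-bonded carbon. This places 5-methyl-1H-imidazol-1-yl in place of pyrrolidin-1-yl on a saturated chain carbon bound to a triple-bonded carbon.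

Among the measured compounds shown here, the only measured step offers little guidance. It is a step that the two limits leave unreadable from compound 2 to compound 3, and it concerns methyl in place of hydrogen, not the group exchanged here. The better pointer is compound 1, which already carries 5-methyl-1H-imidazol-1-yl and gives 80 mg/kg, a measured number. However, compound 1 also differs from compound 4 in the group on the amide-type nitrogen, so the pointer is indirect.

On the strength of compound 1 at 80 mg/kg, a modest shift toward less compound needed is expected. A limit nevertheless remains quite possible for compound 4. The expected change is an at least 1.1-fold lower number from compound 3 to compound 4 (0.07 log units; that floor lies within the scatter). For compound 4 the estimated value is 85 mg/kg, with an expected range from 35 mg/kg to 200 mg/kg.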

Compound 4, dose for half-maximal effect: 30 mg/kg
Compound 4: the middle estimate sits 2.8-fold (0.45 log units) above what was measured; measured number outside the range, below it.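

In this assay, among the compounds shown here, 5-methyl-1H-imidazol-1-yl in place of pyrrolidin-1-yl on a saturated chain carbon bound to a triple-bonded carbon gives the first step that can be read for this position, an at least 3.3-fold lower number from compound 3 to compound 4 (0.52 log units; beyond the scatter), and it lies beyond the scatter. Going by these compounds, compound 3 stands at a limit, so this step gives only a floor, and its true size stays unknown: the limit of > 100 mg/kg in this assay, at which 2 of the 4 values shown sit. With 5-methyl-1H-imidazol-1-yl in place, the group on the carbonyl carbon also shows a readable effect, as ethoxy in place of methyl gives a 2.7-fold lower number from compound 1 to compound 4 (0.43 log units; beyond the scatter), so the gain in compound 4 rests on more than one part of the structure.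

On these data alone, compound 2 and compound 3 both stand at a limit and the step between them cannot be read, so the effect of methyl in place of hydrogen on the chain carbon stays open, including whether it holds with 5-methyl-1H-imidazol-1-yl present. Also open, as far as these compounds go, is how an unsubstituted imidazol-1-yl or a piperidin-1-yl would compare at this position, and how a longer group such as propoxy would fare on the carbonyl carbon.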